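Chloro-to-methyl swap on two cores of the series

The source may report more compounds than this note shows. Statements on the series, on what has been measured and on what is new or still open speak of the compounds shown alone.

Measured so far, in a functional assay (Cavia porcellus) with sulfonylurea receptors; K-ATP channels (Homo sapiens) as the target; a higher number here means a weaker inhibitor, a lower number a stronger inhibitor:
compound 1, `CC(O)(C(=O)Nc1ccc(S(=O)(=O)c2cccc(Cl)c2)cc1)C(F)(F)F`, gives 10000 nM.
compound 2, `Cc1cccc(S(=O)(=O)c2ccc(NC(=O)C(C)(O)C(F)(F)F)cc2)c1`, gives 2200 nM.
compound 3, `CC(O)(C(=O)Nc1ccc(C(=O)c2ccccc2)cc1Cl)C(F)(F)F`, gives only a limit of the assay, > 30000 nM.

The change methyl in place of chloro on an aromatic carbon gives a 4.5-fold lower number from compound 1 to compound 2 (0.66 log units; beyond the scatter). Compound 4, `Cc1cc(C(=O)c2ccccc2)ccc1NC(=O)C(C)(O)C(F)(F)F`, has not yet been measured in this assay. Compound 4 carries the same kind of change relative to compound 3, (methyl in place of chloro on an aromatic carbon). The place is not the same: in compound 4 it is ortho to a large group and meta to a benzoyl group, whereas in compound 2 it is meta to a large group. The difference between the two cores, compound 1 against compound 3, is not broken down here. Compound 3 sits at the limit of > 30000 nM in this assay, at which 1 of the 3 values shown sits, so the starting point for compound 4 is a limit rather than a number. If the change runs as it did between compound 1 and compound 2, compound 4 is expected to move by an at least 2.0-fold lower number from compound 3 to compound 4 (0.30 log units; that floor lies within the scatter). Compound 4 is thus estimated at 15000 nM, plausibly between 5000 nM and 50000 nM, and a limit rather than a number remains possible.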

Compound 4, half-maximal inhibitory concentration: 5000 nM
Beside the measured number, compound 4's estimate is 3.0-fold (0.48 log units) above it, and the stated range covers the measured number.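

In this assay, methyl in place of chloro gives an at least 6.0-fold lower number from compound 3 to compound 4 (0.77 log units; beyond the scatter), so the number falls on this core too, and both steps lie beyond the scatter: the same change on two cores in this assay, a 4.5-fold lower number (0.66 log units; beyond the scatter) from compound 1 to compound 2 and an at least 6.0-fold lower number (0.77 log units; beyond the scatter) from compound 3 to compound 4; the limit leaves it open whether they differ. Compound 3 gives > 30000 nM, which is a limit of the assay and not a number. The two pairs show that the direction of the change carried from one core to the other, with the methyl in a different place on each core, but they do not show that its size carried over, nor that the direction would hold on any further core.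

Going by these compounds, whether an ethyl, a methoxy or a nitrile in the place of the methyl would give a similar step remains open on both cores.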